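This account rests on a few compounds, and the source may have more. Where it says the series, first, only, none or still open, it means among the compounds named here.

The measured compounds and their values:

Compound 1, `Cc1c(-c2csc(NC(=S)Nc3ccccc3)n2)c(=O)n(-c2ccccc2)n1C`, gives 7740 nM.
Compound 2, `Cc1c(-c2csc(/N=c3\sc(-c4ccccc4)nn3-c3ccccc3)n2)c(=O)n(-c2ccccc2)n1C`, gives > 100000 nM.
Compound 3, `Cc1c(-c2csc(/N=C3\S/C(=C\c4ccc(Cl)cc4)C(=O)N3c3ccccc3)n2)c(=O)n(-c2ccccc2)n1C`, gives > 100000 nM.

All three were tested in a functional assay on A549 cells (Homo sapiens) for cytotoxicity, read by sulforhodamine B assay, with a stated time of 72 h; on this read-out higher numbers stand for weaker inhibition and lower numbers for stronger inhibition. Compound 1 is the only one with a numerical result, at 7740 nM. For compound 2 the reported value of > 100000 nM is a limit of the assay, not a number. From the compounds shown here alone, for compound 3 the value of > 100000 nM is likewise a limit, so where compound 3 truly stands is unknown beyond that boundary. Two of the three values sit at the limit of > 100000 nM in this assay, at which 2 of the 3 values shown sit, and compound 3 is one of them.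

Compound 4, `COc1ccc(/C=C2\S/C(=N\c3nc(-c4c(C)n(C)n(-c5ccccc5)c4=O)cs3)N(c3ccccc3)C2=O)cc1`, differs from compound 3 in one place: methoxy in place of chloro on an aromatic carbon. Within the data shown here, no measured pair shows what such a swap does in this assay, so there is nothing to lean on but the position of compound 3 itself. With compound 3 already at the limit, compound 4 is expected to stay there as well, and the step of a number no higher from compound 3 to compound 4 (the limit leaves the size open) is expected to be none beyond the scatter. The estimate for compound 4 is 100000 nM, with a range from 30000 nM to 300000 nM.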

Compound 4, half-maximal inhibitory concentration: 9100 nM
The estimate for compound 4 lay 11-fold (1.04 log units) above the measured number, and the stated range ends above it.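

In this assay, changing 4-chlorophenyl to 4-methoxyphenyl gives an at least 10-fold lower number from compound 3 to compound 4 (1.04 log units; beyond the scatter), so this position on the ring can decide whether the series registers in the assay at all, and a swap of one small group is enough to do it. Among these compounds, compound 4, at 9100 nM, also shows that the shared framework of compound 3 can give a measurable number, which the earlier compounds could not show since none of them formed a pair differing in one place. The true size of the step stays open on one side, because compound 3 carries a limit and not a number: the limit of > 100000 nM in this assay, at which 2 of the 4 values shown sit.

A single pair cannot separate what methoxy brings from what the loss of chloro removes, and a plain hydrogen, a hydroxyl, a fluoro or a dimethylamino group at the same place would be needed to tell whether the gain belongs to methoxy specifically. From the compounds shown here alone, it also remains open whether the same swap would act the same way on a different framework, such as that of compound 2.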